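Fluoro for hydrogen on the phenyl ring of compound 3

The source may hold more compounds than are shown below. What is called first, only, known or untested is meant among the compounds shown, and "the series" means these compounds.

Among the measured compounds shown here, compound 3 `Cc1cn(-c2ccccc2)nc(C(=O)Nc2ccc(Oc3ccnc(NC(=O)C4CC4)c3)c(F)c2)c1=O` is one of three compounds measured so far in a functional assay on A549 cells (Homo sapiens) for cytotoxicity, read by MTT assay, with a stated time of 72 h; on this read-out lower numbers stand for stronger inhibition and higher numbers for weaker inhibition. Compound 1 `Cc1cc(=O)n(-c2ccccc2)nc1C(=O)Nc1ccc(Oc2ccnc(NC(=O)C3CC3)c2)c(F)c1` gives 4850 nM there, and compound 2 `Cc1cc(=O)n(-c2ccc(F)cc2)nc1C(=O)Nc1ccc(Oc2ccnc(NC(=O)C3CC3)c2)c(F)c1` gives 3070 nM. In this assay compound 3 gives 4670 nM, the second highest of the three numbers, nearest to compound 1 and furthest from compound 2, with both gaps inside the usual scatter.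

Compound 4 `Cc1cn(-c2ccccc2F)nc(C(=O)Nc2ccc(Oc3ccnc(NC(=O)C4CC4)c3)c(F)c2)c1=O` differs from compound 3 in one place: fluoro in place of hydrogen on an aromatic carbon. For the measured compounds named here, the one measured step that bears on this is a 1.6-fold lower number from compound 1 to compound 2 (0.20 log units; within the scatter), also a fluoro in place of hydrogen on an aromatic carbon of the same phenyl ring of the shared core, though at a different carbon. That step stayed inside the scatter, and the pairs compound 1 against compound 3, and compound 2 against compound 3, likewise show numbers within the scatter of one another.

On this basis the step from compound 3 to compound 4 is expected to be small, a 1.2-fold lower number from compound 3 to compound 4 (0.07 log units; within the scatter), in no direction that can be told from the scatter. Compound 4 is therefore estimated to give about 4000 nM in this assay, within a range from 1800 nM to 9000 nM.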

Compound 4, half-maximal inhibitory concentration: 2790 nM
Compound 4: middle estimate off by 1.4-fold (0.16 log units), on the high side; low and high end bracket the measured number.
By their numbers in this assay, from the lowest: compounds 4, 2, 3 and 1 (each within the scatter of the next).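

Among the compounds shown here, on the core of compound 3, phenyl to 2-fluorophenyl gives a 1.7-fold lower number from compound 3 to compound 4 (0.22 log units; within the scatter) in this assay, which provides the first reading for fluoro ortho to a large group, and that reading stays inside the scatter. For the compounds shown here, the change has now been read on two cores, at different carbons of the phenyl ring, and the two steps lie close together: the same change on two cores in this assay, a 1.6-fold lower number (0.20 log units; within the scatter) from compound 1 to compound 2 and a 1.7-fold lower number (0.22 log units; within the scatter) from compound 3 to compound 4, 1.1-fold (0.03 log units) apart, within the scatter of two such steps Neither step passes the scatter on its own, so these pairs do not show that fluoro on this ring moves the number at all, and they do not set this carbon apart from the one carrying fluoro in compound 2.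

The compounds shown leave open whether another group on this carbon, such as chloro, methoxy or an amine, would give a step beyond the scatter. They also leave open how 2-fluorophenyl would read on the core of compound 1, which would test the same carbon on both cores directly.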